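Aryl group variation on the shared core, next step

This account rests on a few compounds, and the source may have more. Where it says the series, first, only, none or still open, it means among the compounds named here.

Compound 1 `O=C(O)Cc1sc(C(c2ccc(F)cc2)c2ccc(F)cc2)nc1-c1ccccc1` anchors the series; in an in vitro assay on HEK385-7 cells for displacement of a labelled ligand from prostaglandin D2 receptor 2 (Homo sapiens) (a higher number here means a weaker inhibitor, a lower number a stronger inhibitor), compound 1 gives 16 nM. Compound 2 `O=C(O)Cc1sc(C(c2ccc(F)cc2)c2ccc(F)cc2)nc1-c1cccc(F)c1` carries an added fluoro and in this assay compound 2 gives 1.4 nM, the change being an 11-fold lower number from compound 1 to compound 2 (1.06 log units; beyond the scatter). Within the data shown here, compound 3 `N#Cc1ccc(-c2nc(C(c3ccc(F)cc3)c3ccc(F)cc3)sc2CC(=O)O)cc1` carries a cyano instead and in this assay compound 3 gives 150 nM; this is the highest of the three numbers so far, with a 9.4-fold higher number from compound 1 to compound 3 (0.97 log units; beyond the scatter) and a 110-fold higher number from compound 2 to compound 3 (2.03 log units; beyond the scatter).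

Compound 4 `NS(=O)(=O)c1cccc(-c2nc(C(c3ccc(F)cc3)c3ccc(F)cc3)sc2CC(=O)O)c1` is not yet measured. Its difference from compound 3 is 3-sulfamoylphenyl in place of 4-cyanophenyl on an aromatic carbon. Among the measured compounds shown here, two measured steps bear on it. The cyano that is removed cost a 9.4-fold higher number from compound 1 to compound 3 (0.97 log units; beyond the scatter), so taking it away should return the number toward that of compound 1. For the measured compounds named here, a group entering at the 3-position of the phenyl ring, in compound 2, brought an 11-fold lower number from compound 1 to compound 2 (1.06 log units; beyond the scatter), but a sulfamoyl is not a fluoro, and no measured compound carries a sulfamoyl, so that gain is uncertain.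

Taken together, a step to a lower number beyond the scatter is expected, a 7.5-fold lower number from compound 3 to compound 4 (0.88 log units; beyond the scatter), and compound 4 is estimated at 20 nM within a range of 4 nM to 100 nM.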

Compound 4, half-maximal inhibitory concentration: 140 nM
Compound 4: middle estimate off by 7.0-fold (0.85 log units), on the low side; the measured number lies above the stated range.
By their numbers in this assay, from the lowest: compound 2; then compound 1; then compounds 4 and 3 (each within the scatter of the next).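

In this assay, 3-sulfamoylphenyl in place of 4-cyanophenyl gives a 1.1-fold lower number from compound 3 to compound 4 (0.03 log units; within the scatter), so the two groups cannot be told apart at this position, next to the ring nitrogen, although they differ in both the group and its place on the phenyl ring. Compared with the unsubstituted phenyl, sulfamoyl in place of hydrogen gives an 8.8-fold higher number from compound 1 to compound 4 (0.94 log units; beyond the scatter), and sulfamoyl in place of fluoro gives a 100-fold higher number from compound 2 to compound 4 (2.00 log units; beyond the scatter), so the gain seen with 3-fluorophenyl in compound 2 does not carry over to 3-sulfamoylphenyl, and of the substituted phenyl groups shown only that of compound 2 goes against the rise seen in compounds 3 and 4. No measurement on hand accounts for this result.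

The compounds shown do not separate the effect of the group from the effect of its place on the phenyl ring, a question that 3-cyanophenyl and 4-sulfamoylphenyl would address. Also open, from the compounds shown here alone, is how other groups on the phenyl ring compare with fluoro and sulfamoyl, such as a chloro, a methoxy, an amine or a carboxylic acid.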